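Moving a trifluoromethyl group on the hydrazone side

The compounds below may be only part of what the source reports. "The series", "measured", "known", "first", "only" and "open" are said of these compounds alone.

Measured so far, in a functional assay on HeLa cells (Homo sapiens) for inhibition, read by MTT assay, with a stated time of 72 h; a lower number here means a stronger inhibitor, a higher number a weaker inhibitor:
Compound 1, `CN(C(=O)NC(=O)c1ccc(F)c(F)c1)c1nc(C(F)(F)F)c(C(=O)N/N=C/c2ccc(C(F)(F)F)cc2)s1`: 5.1 ug/mL
Compound 2, `CN(C(=O)NC(=O)c1cccc(C(F)(F)F)c1)c1nc(C(F)(F)F)c(C(=O)N/N=C/c2ccc(C(F)(F)F)cc2)s1`: 7.35 ug/mL
Compound 3, `CN(C(=O)NC(=O)c1ccc(C(F)(F)F)cc1)c1nc(C(F)(F)F)c(C(=O)N/N=C/c2ccc(C(F)(F)F)cc2)s1`: > 100 ug/mL, which is a limit of this assay, not a number.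

Compound 1 holds the lowest of the two numbers shown, with compound 2 close by a 1.4-fold higher number from compound 1 to compound 2 (0.16 log units; within the scatter). Compound 3 sits at the limit (the limit of > 100 ug/mL in this assay, at which 1 of the 3 values shown sits), giving the steps of an at least 19-fold higher number from compound 1 to compound 3 (1.29 log units; beyond the scatter) and an at least 13-fold higher number from compound 2 to compound 3 (1.13 log units; beyond the scatter).

Compound 4, `CN(C(=O)NC(=O)c1ccc(F)c(F)c1)c1nc(C(F)(F)F)c(C(=O)N/N=C/c2cccc(C(F)(F)F)c2)s1`, differs from compound 1 by 3-(trifluoromethyl)phenyl in place of 4-(trifluoromethyl)phenyl on a carbon with a double bond to nitrogen. The measured steps all concern the other aryl group, the one on a carbonyl carbon; none touches the hydrazone side, so they do not bear directly on this change. Among the compounds with values here, with no direct precedent, compound 4 is expected to stay near compound 1, a step of a 1.2-fold higher number from compound 1 to compound 4 (0.07 log units; within the scatter), so that compound 4 is estimated at 6 ug/mL, in the range 2.5 ug/mL to 20 ug/mL.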

Compound 4, half-maximal inhibitory concentration: 4.21 ug/mL
For compound 4 the middle estimate is 1.4-fold (0.15 log units) above the measured one; the measured number falls inside the stated range.
By their numbers in this assay, from the lowest: compounds 4, 1 and 2 (each within the scatter of the next). At a limit, above all of these: compound 3.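

With 3-(trifluoromethyl)phenyl in place of 4-(trifluoromethyl)phenyl on a carbon with a double bond to nitrogen, this assay shows a 1.2-fold lower number from compound 1 to compound 4 (0.08 log units; within the scatter), so at this position the change makes no clear difference. The same change made on a carbonyl carbon has a far larger effect, so its outcome depends on where it is made: the same change on two cores in this assay, an at least 13-fold higher number (1.13 log units; beyond the scatter) from compound 2 to compound 3 and a 1.2-fold higher number (0.08 log units; within the scatter) from compound 4 to compound 1, at least 11-fold (1.05 log units) apart, beyond the scatter of two such steps

As far as these compounds go, it remains open whether this position accepts a ring carrying an amine or a carboxylic acid instead of trifluoromethyl. Also open, from the compounds shown here alone, is whether 3-(trifluoromethyl)phenyl here would alter the result when paired with the 4-(trifluoromethyl)phenyl on the carbonyl carbon of compound 3.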